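From an Open-Chain Amine to a Five-Membered Ring

The source may hold more compounds than are shown below. What is called first, only, known or untested is meant among the compounds shown, and "the series" means these compounds.

Of the compounds shown here, three sharing one core have been tested in a functional assay on NALM-6 cells (Homo sapiens) for cytotoxicity, read by MTT assay, with a stated time of 48 h; on this read-out higher numbers stand for weaker inhibition and lower numbers for stronger inhibition. Compound 1 `O=C(Nc1cc(C(F)(F)F)ccc1N1CCCCC1)c1ccccc1` gives "not active" (no number reported) in this assay; no number was reported for it. Compound 2 `O=C(Nc1cc(C(F)(F)F)ccc1Nc1ccc(Br)cc1)c1ccccc1` is the only one of the three with a numerical result, giving 6000 nM in this assay. Compound 3 `CCN(CC)c1ccc(C(F)(F)F)cc1NC(=O)c1ccccc1` likewise gives "not active" (no number reported) in this assay, again with no number attached, so compound 3 stands among the entries that did not reach a measurable result, alongside compound 1.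

Compound 4 `O=C(Nc1cc(C(F)(F)F)ccc1N1CCCC1)c1ccccc1` has not yet been measured. It differs from compound 3 in a single place: pyrrolidin-1-yl in place of diethylamino on an aromatic carbon. Going by the values given here, since no measured pair shows this kind of change, there is no step to lean on, only the observation that compound 1 and compound 3, the two neighbours carrying an amine of the same kind, both came back without a number. The change from compound 3 to compound 4 is therefore expected to produce no shift beyond the scatter in this assay.

Compound 4 is estimated at 40000 nM in this assay, within a range from 10000 nM to 150000 nM, with a high chance that only an inactive result and no number is reported.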

Compound 4, half-maximal inhibitory concentration: "not active" (no number reported)
For compound 4 the study gives words and no number; the estimate stays without a comparison.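

Compound 3 and compound 4 both come back from this assay without a number, so no step can be read between them, and no measured evidence bears on this result. The compounds shown leave open whether any saturated amine on the shared core can give a measurable value.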